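From bromo to nitro: tolerability in a cytotoxicity screen

The source may hold more compounds than are shown below. What is called first, only, known or untested is meant among the compounds shown, and "the series" means these compounds.

Compound 2 `COc1cc(OCC=C(C)C)ccc1C(=O)/C=C/c1ccc(Br)cc1` has been measured in an ADME assay on THP-1 cells (Homo sapiens) for cytotoxicity, read by resazurin assay, with a stated time of 72 h (a lower number here means that less compound is tolerated, a higher number that more compound is tolerated), where compound 2 gives 100000 nM. Going by the values given here, that is the higher of the two numbers known so far; the other belongs to compound 1 `COc1cc(OCC=C(C)C)ccc1C(=O)/C=C/c1cccnc1`, which in this assay gives 40000 nM. Among the compounds with values here, the single step connecting them, a 2.5-fold higher number from compound 1 to compound 2 (0.40 log units; beyond the scatter), is modest yet beyond the scatter. Compound 3 `COc1cc(OCC=C(C)C)ccc1C(=O)/C=C/c1ccc([N+](=O)[O-])cc1` has not yet been tested in this assay. It differs from compound 2 by nitro in place of bromo on an aromatic carbon. Within the data shown here, no measured step exchanges one substituent for another on that same ring; the only step available, a 2.5-fold higher number from compound 1 to compound 2 (0.40 log units; beyond the scatter), replaces the whole aryl group and therefore bears only loosely on the present change. With nothing pointing firmly in either direction, the step is expected to remain within the usual scatter, perhaps edging slightly downward: a 1.4-fold lower number from compound 2 to compound 3 (0.15 log units; within the scatter). Compound 3 is accordingly estimated at 70000 nM, with a plausible range from 30000 nM to 150000 nM.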

Compound 3, half-maximal cytotoxic concentration: 600000 nM
Beside the measured number, compound 3's estimate is 8.6-fold (0.93 log units) below it; the measured number lies above the stated range.
By their numbers in this assay, from the lowest: compound 1; then compound 2; then compound 3.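

At a position para to a large group on the aromatic ring, exchanging a single substituent is enough to shift the result in this assay: nitro in place of bromo gives a 6.0-fold higher number from compound 2 to compound 3 (0.78 log units; beyond the scatter) and so shows that this one position matters, which the earlier step could not show since it replaced the whole aryl group. The change of aryl group also gains a much wider span, with 4-nitrophenyl in place of pyridin-3-yl giving a 15-fold higher number from compound 1 to compound 3 (1.18 log units; beyond the scatter) and placing compound 3 highest of the three, with its steps to both others beyond the scatter. Nothing available explains why nitro in place of bromo has this effect.

As far as these compounds go, whether the rise is particular to nitro remains open, since an amine, a carboxylic acid or a nitrile at the same position could show whether other groups go the same way. From the compounds shown here alone, it is also open whether the exchange of bromo for nitro would give a similar step on a core carrying a longer chain at its ether oxygen.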